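From 3-bromobenzyl to allyl on the ring nitrogen

The source may report more compounds than this note shows. Statements on the series, on what has been measured and on what is new or still open speak of the compounds shown alone.

The three measured compounds share a core that carries a phenylpiperazine and a hydroxyl on a saturated ring, and differ in the group on the ring nitrogen. Compound 1 `OC1CN(Cc2cccc(Br)c2)CCC1N1CCN(c2ccccc2)CC1` gives 66 nM in an assay on PC-12 cells for displacement of a labelled ligand from vesicular acetylcholine transporter (Homo sapiens); on this read-out lower numbers stand for stronger inhibition and higher numbers for weaker inhibition. Compound 3 `OC1CCN(Cc2cccc(Br)c2)CC1N1CCN(c2ccccc2)CC1` gives 46 nM in this assay, a number that sits within the usual scatter of the number for compound 1. Compound 2 `OC1CN(Cc2ccc(Br)cc2)CCC1N1CCN(c2ccccc2)CC1` gives only a limit of the assay, > 100 nM, in this assay. The one step computed among these, an at least 1.5-fold higher number from compound 1 to compound 2 (0.18 log units; that floor lies within the scatter), moves the bromine on the ring and reaches the limit (the limit of > 100 nM in this assay, at which 1 of the 3 values shown sits). Compound 4 `C=CCN1CCC(O)C(N2CCN(c3ccccc3)CC2)C1` is not yet measured. It differs from compound 3 by vinyl in place of 3-bromophenyl on a saturated chain carbon bound to an amine nitrogen in a ring. Among the measured compounds shown here, no measured step removes the aromatic ring altogether, so the moving of bromine is the only guide, and it points toward a higher number. Compound 4 is therefore expected to give 300 nM in this assay, between 70 nM and 2000 nM, a step of a 6.5-fold higher number from compound 3 to compound 4 (0.81 log units; beyond the scatter).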

Compound 4, half-maximal inhibitory concentration: > 100 nM
Compound 4: only a limit was reported; the forecaster's own chance of this, stated with the estimate: 60%; the middle value does not contradict the limit.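

In this assay, replacing 3-bromobenzyl with allyl on the ring nitrogen gives an at least 2.1-fold higher number from compound 3 to compound 4 (0.33 log units; beyond the scatter), so at this position losing the aromatic ring and its bromine carries a real cost. The only earlier step, an at least 1.5-fold higher number from compound 1 to compound 2 (0.18 log units; that floor lies within the scatter), moved the bromine and stayed within the scatter, which makes this the first change shown to clear it. Compound 4 sits at a limit of the assay, so the new step gives only a floor and not a true size: the limit of > 100 nM in this assay, at which 2 of the 4 values shown sit.

This change removes the ring and the bromine together, so the compounds shown cannot tell which of the two accounts for the loss. A plain benzyl group without bromine on the same nitrogen would separate the two, and a longer chain such as hexyl would show whether a larger group without an aromatic ring does any better than allyl.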